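The source may hold more compounds than are shown below. What is called first, only, known or untested is meant among the compounds shown, and "the series" means these compounds.

Within the data shown here, in an ADME assay on microsomes from liver (Mus musculus) for metabolic stability, with a stated time of 10 min, tested at 0.5 uM (on this read-out lower numbers stand for a less stable compound and higher numbers for a more stable compound), compound 1 `Cc1noc(C)c1[C@@H]1C[C@@](C)(c2ccc(F)cc2F)N=C(N)S1` gives 72% and compound 2 `Cn1nccc1[C@@H]1C[C@@](C)(c2ccc(F)cc2F)N=C(N)S1` gives 72%, so compound 2 stands level with the only other measured compound. Compound 3 `C[C@@]1(c2ccc(F)cc2F)C[C@@H](c2cncnc2)SC(N)=N1` has not yet been measured. It has pyrimidin-5-yl in place of 1-methyl-1H-pyrazol-5-yl on a saturated ring carbon, next to the ring sulfur: pyrimidin-5-yl in place of 1-methyl-1H-pyrazol-5-yl on a saturated ring carbon. Among the measured compounds shown here, the one measured step that bears on this swap, made on the same ring carbon, shows no change at the digits printed from compound 1 to compound 2 (within the scatter), with 1-methyl-1H-pyrazol-5-yl in place of 3,5-dimethyl-1,2-oxazol-4-yl. For the measured compounds named here, that single step offers only a thin guide, and no measured compound here carries a six-membered aromatic ring at this place. With that flat step from compound 1 to compound 2 as the guide, the expected step in this assay is a number 2 percentage points lower from compound 2 to compound 3 (within the scatter), which means no expected shift beyond the scatter. For compound 3 the estimated value is 70%, with an expected range from 52% to 85%.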

Compound 3, percent of the compound remaining: 68%
Estimate against measurement, compound 3: 2 percentage points above, within the range that was stated.
By their numbers in this assay, from the lowest: compounds 3, 1 and 2 (each within the scatter of the next).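

In this assay, among these compounds, a six-membered aromatic ring sits on this saturated ring carbon for the first time, and pyrimidin-5-yl in place of 1-methyl-1H-pyrazol-5-yl gives a number 4 percentage points lower from compound 2 to compound 3 (within the scatter) on this read-out. Against 3,5-dimethyl-1,2-oxazol-4-yl, the same group gives a number 4 percentage points lower from compound 1 to compound 3 (within the scatter) at this place, so among these three compounds a change from a five-membered to a six-membered aromatic ring moves the number no further than the usual scatter. Nothing available explains this flat result.

As far as these compounds go, all three groups here are aromatic rings with hetero atoms, so it remains open whether a plain phenyl ring would also read alike. From the compounds shown here alone, it also remains open whether a group of another kind on this ring carbon, such as an amine or a carboxylic acid, would shift the number beyond the scatter.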